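Fluoro on the methoxyphenyl ring of the free alcohol

The source may report more compounds than this note shows. Statements on the series, on what has been measured and on what is new or still open speak of the compounds shown alone.

The shared core is seen in compound 2 `COc1ccc(C2=C(c3cc(OC)c(OC)c(OC)c3)C(=O)C(O)C2)cc1`, the free alcohol. In an ADME assay on DU-145 cells (Homo sapiens) for cytotoxicity, read by MTT assay, with a stated time of 72 h (a lower number here means a stronger inhibitor, a higher number a weaker inhibitor), compound 2 gives only a limit, > 100 ug/mL, one of the readings that sit at the assay ceiling (the limit of > 100 ug/mL in this assay, at which 1 of the 3 values shown sits). Capping that hydroxyl is the one measured step: from compound 2 to compound 3 `COc1ccc(C2=C(c3cc(OC)c(OC)c(OC)c3)C(=O)C(O[SiH2]C(C)(C)C)C2)cc1` the change is an at least 3.5-fold lower number from compound 2 to compound 3 (0.55 log units; beyond the scatter), compound 3 giving 28 ug/mL. Compound 1 `COc1ccc(C2=C(c3cc(OC)c(OC)c(OC)c3)C(=O)C(OC(C)=O)C2)cc1F`, with both fluoro and an acetate, gives 16 ug/mL, but it differs from compound 2 in two places, so it does not isolate either change. Compound 4 `COc1ccc(C2=C(c3cc(OC)c(OC)c(OC)c3)C(=O)C(O)C2)cc1F` differs from compound 2 by fluoro in place of hydrogen on an aromatic carbon. Going by the values given here, no measured step tests this change alone. For compound 4 a step of an at least 1.6-fold lower number from compound 2 to compound 4 (0.22 log units; that floor lies within the scatter) is expected, a modest gain that may still leave it near the limit. Compound 4 is estimated at 60 ug/mL, between 25 ug/mL and 120 ug/mL.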

Compound 4, half-maximal inhibitory concentration: 27 ug/mL
For compound 4 the middle estimate is 2.2-fold (0.35 log units) above the measured one; the measured number falls inside the stated range.
By their numbers in this assay, from the lowest: compounds 1, 4 and 3 (each within the scatter of the next). At a limit, above all of these: compound 2.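

Fluoro in place of hydrogen, ortho to the methoxy group, gives an at least 3.7-fold lower number from compound 2 to compound 4 (0.56 log units; beyond the scatter) with the hydroxyl left free, so capping that hydroxyl is not required to come off the limit. From the compounds shown here alone, compound 2 stands at a limit, so the full size of this step stays unknown: the limit of > 100 ug/mL in this assay, at which 1 of the 4 values shown sits. With fluoro present, going from acetate to free hydroxyl gives a 1.7-fold higher number from compound 1 to compound 4 (0.23 log units; within the scatter) and no difference can be told apart.

Open, going by these compounds, is whether chloro or an amine at the same place would serve as fluoro does. Also open, on these data alone, is whether fluoro adds to the silyl ether of compound 3.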